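Lengthening the chain from propyl to butyl

A few compounds are considered here, and "the series" means these few. Any claim that something is new, unique, unknown or untested is made for them only; others in the source may bear on it.

- compound 1 `Cn1ccnc1/C=C/C(=O)/C=C/c1coc2ccccc2c1=O`: 2300 nM
- compound 2 `CCn1ccnc1/C=C/C(=O)/C=C/c1coc2ccccc2c1=O`: 1000 nM
- compound 3 `CCCn1ccnc1/C=C/C(=O)/C=C/c1coc2ccccc2c1=O`: 2100 nM

Two steps place compound 3 in a functional assay on LNCaP cells (Homo sapiens) for inhibition, read by WST assay, with a stated time of 3 days; a higher number here means a weaker inhibitor, a lower number a stronger inhibitor: there is a 1.1-fold lower number from compound 1 to compound 3 (0.04 log units; within the scatter), and there is a 2.1-fold higher number from compound 2 to compound 3 (0.32 log units; beyond the scatter). Compound 3 therefore sits level with compound 1, while compound 2 has the lowest number of the three.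

The next compound, compound 4 `CCCCn1ccnc1/C=C/C(=O)/C=C/c1coc2ccccc2c1=O`, carries butyl where compound 3 carries propyl. The change is methyl in place of hydrogen on a saturated chain carbon, three bonds along the chain from an aromatic nitrogen.

The best guides are the two earlier single-carbon extensions of this chain. The first gave a 2.3-fold lower number from compound 1 to compound 2 (0.36 log units; beyond the scatter), and the second gave a 2.1-fold higher number from compound 2 to compound 3 (0.32 log units; beyond the scatter). Both steps were modest and ran in opposite directions, so together they set no direction for the next one. No step beyond the scatter is expected in this assay, though a modest one either way remains possible. The expected result is a 1.1-fold lower number from compound 3 to compound 4 (0.02 log units; within the scatter). Compound 4 is estimated at 2000 nM, with an expected range of 900 nM to 4500 nM.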

Compound 4, half-maximal inhibitory concentration: 2000 nM
Compound 4: the middle estimate sits on the measured number at the digits printed, and the stated range covers the measured number.
By their numbers in this assay, from the lowest: compounds 2, 4, 3 and 1 (each within the scatter of the next, the first and the last beyond it).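

In this assay, methyl in place of hydrogen on a saturated chain carbon, three bonds along the chain from an aromatic nitrogen, gives a 1.1-fold lower number from compound 3 to compound 4 (0.02 log units; within the scatter), the only one of the three single-carbon extensions that stays within the scatter. Butyl is also within the scatter of both shorter chains, with a 1.2-fold lower number from compound 1 to compound 4 (0.06 log units; within the scatter) and a 2.0-fold higher number from compound 2 to compound 4 (0.30 log units; within the scatter), so compound 4 is separated from none of the other three compounds. The same methyl change therefore gives steps of different printed size at two places on the chain, yet even that contrast cannot be pressed: the same change on two cores in this assay, a 2.3-fold lower number (0.36 log units; beyond the scatter) from compound 1 to compound 2 and a 1.1-fold lower number (0.02 log units; within the scatter) from compound 3 to compound 4, 2.2-fold (0.34 log units) apart, within the scatter of two such steps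

The compounds shown leave open whether a longer chain, such as pentyl or hexyl, would stay level with butyl. They also leave open what an amine or a carboxylic acid at the end of the chain would do.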